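The source may hold more compounds than are shown below. What is called first, only, known or untested is meant among the compounds shown, and "the series" means these compounds.

Measured so far in an assay on Sf9 cells for inhibition of protein deacetylase HDAC6 (Homo sapiens), read by fluorescence, with a stated time of 40 min, tested at 100 nM; a higher number here means more inhibition at the concentration tested (going by the name of the read-out), a lower number less inhibition:
compound 1 `Cc1ccccc1-n1nc(-c2ccccc2)nc1CNc1ccc(C(=O)NO)cc1` — compound 1 gives 57.1%
compound 2 `COc1ccc(-n2nc(-c3ccccc3)nc2CNc2ccc(C(=O)NO)cc2)cc1` — compound 2 gives 63.4%
compound 3 `CC(C)c1ccc(-n2nc(-c3ccccc3)nc2CNc2ccc(C(=O)NO)cc2)cc1` — compound 3 gives 52.6%

Of the three numbers, compound 3 holds the smallest, though its gap to compound 1 lies within the scatter; against compound 2 the step is a number 10.8 percentage points lower from compound 2 to compound 3 (beyond the scatter).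

Compound 4 `Cc1ccc(-n2nc(-c3ccccc3)nc2CNc2ccc(C(=O)NO)cc2)cc1C` differs from compound 3 in one place: 3,4-dimethylphenyl in place of 4-isopropylphenyl on an aromatic nitrogen. Among the measured compounds shown here, the steps that bear on this change are those that swap the group on the same aromatic nitrogen: a number 4.5 percentage points lower from compound 1 to compound 3 (within the scatter) and a number 10.8 percentage points lower from compound 2 to compound 3 (beyond the scatter). Both are small, one within the scatter, one just beyond it. For the measured compounds named here, no measured step involves 3,4-dimethylphenyl itself. The expectation for this assay is therefore a step of a number 2.4 percentage points higher from compound 3 to compound 4 (within the scatter), not beyond the scatter. For compound 4 the estimate is 55%, with a range from 42% to 68%.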

Compound 4, a percentage reported as inhibition, at one concentration (the size of the read-out at that concentration, not a potency): 53%
Beside the measured number, compound 4's estimate is 2 percentage points above it; low and high end bracket the measured number.
By their numbers in this assay, from the lowest: compounds 3, 4, 1 and 2 (each within the scatter of the next, the first and the last beyond it).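

In this assay the step to 3,4-dimethylphenyl on the aromatic nitrogen is a number 0.4 percentage points higher from compound 3 to compound 4 (within the scatter) and so cannot be told apart from 4-isopropylphenyl. Against 2-methylphenyl the step is a number 4.1 percentage points lower from compound 1 to compound 4 (within the scatter) and against 4-methoxyphenyl it is a number 10.4 percentage points lower from compound 2 to compound 4 (beyond the scatter) so 4-methoxyphenyl now stands apart from two of the groups here, though not from 2-methylphenyl. No evidence at hand accounts for these steps. Open, going by these compounds, is whether a phenyl carrying an amine or a carboxylic acid on this nitrogen would leave this band of numbers. Also open, on these data alone, is what replacing the phenyl group on the neighbouring triazole-free position does.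

Correction to the last sentence: also open is what a pyridine in place of the phenyl group on the ring atom that bears it would do.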